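A few compounds are considered here, and "the series" means these few. Any claim that something is new, unique, unknown or untested is made for them only; others in the source may bear on it.

Compound 1 `O=C1C=CC(OCC(F)(F)F)N1c1cc(Cl)cc(Cl)c1` gives 1630 nM in a functional assay on A549 cells (Homo sapiens) for inhibition; a higher number here means a weaker inhibitor, a lower number a stronger inhibitor.
Compound 2 `Cc1ccc(N2C(=O)C=CC2OCC(F)(F)F)cc1` gives 13700 nM in this assay.
Compound 3 `O=C1C=CC(OC(C(F)(F)F)C(F)(F)F)N1c1ccc(Cl)cc1` gives 4300 nM in this assay.

Among these three numbers compound 2 has the highest, so it is the weakest inhibitor of the set. Compound 3 comes nearest to it, and even that number is lower by more than the usual scatter, while compound 1 lies furthest away with a lower number still. Compound 4 `CC(C)(C)c1ccc(N2C(=O)C=CC2OCC(F)(F)F)cc1` keeps everything in compound 2 except one group: tert-butyl in place of methyl on an aromatic carbon. Among the compounds with values here, no pair of measured compounds differs by this single change, so the measured numbers do not show how large a step it brings. The other two compounds differ from compound 2 in several places at once, and their lower numbers cannot be traced to any one of those changes. Given that, only a small step in this assay is expected, with a lean toward a lower number. The estimated step, a 1.7-fold lower number from compound 2 to compound 4 (0.23 log units; within the scatter), is expected to stay within the usual scatter. For compound 4 the expected value in this assay is 8000 nM, within a range from 2500 nM to 25000 nM.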

Compound 4, half-maximal inhibitory concentration: 8500 nM
Estimate against measurement, compound 4: 1.1-fold (0.03 log units) below; measured number inside the range.
By their numbers in this assay, from the lowest: compound 1; then compounds 3, 4 and 2 (each within the scatter of the next, the first and the last beyond it).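

In this assay, within the data shown here, the change from methyl to tert-butyl on this aromatic carbon, para to a large group, gives a 1.6-fold lower number from compound 2 to compound 4 (0.21 log units; within the scatter) and so provides the first direct reading of a single change in this set. Putting a group of 4 heavy atoms where a group of 1 heavy atom stood leaves the two numbers indistinguishable, so for this pair the added carbon atoms bring no measurable difference in inhibition. Nothing available explains why these two compounds read alike.

Both groups compared here are built from carbon and hydrogen alone, so this pair says nothing about how an amine or a carboxylic acid at the same position would read. It also leaves open whether a longer chain, rather than the branched tert-butyl, would give a similar number.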